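The compounds below may be only part of what the source reports. "The series", "measured", "known", "first", "only" and "open" are said of these compounds alone.

In an ADME assay on microsomes from liver (Rattus norvegicus) for metabolic stability, with a stated time of 10 min (a higher number here means that more of the compound is left, a lower number that less of the compound is left), compound 1 (`FC(F)(F)c1ccccc1-c1ccc2[nH]c(C3=NCC4(CCCCC4)O3)nc2c1`) gives 32%, compound 2 (`FC(F)(F)c1ccccc1-c1ccc2[nH]c(C3=NOC4(CCCCC4)C3)nc2c1`) gives 75% and compound 3 (`Fc1cc(-c2ccccc2C(F)(F)F)cc2nc(C3=NOC4(CCCCC4)C3)[nH]c12`) gives 100%, the highest of the three numbers. Compound 4 (`FC(F)(F)c1ccccc1-c1cc(Cl)c2[nH]c(C3=NOC4(CCCCC4)C3)nc2c1`) differs from compound 3 in one place: chloro in place of fluoro on an aromatic carbon. Among the measured compounds shown here, the one measured step at this place is a number 25 percentage points higher from compound 2 to compound 3 (beyond the scatter), a modest step beyond the scatter for fluoro in place of hydrogen. For the measured compounds named here, no measured step exchanges fluoro for chloro, so this is only a loose guide, and a modest downward step is expected in this assay. The expected change is a number 15 percentage points lower from compound 3 to compound 4 (beyond the scatter). For compound 4 the estimated value is 85%, with an expected range of 60% to 100%.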

Compound 4, percent of the compound remaining: 100%
Compound 4: the middle estimate sits 15 percentage points below what was measured, within the range that was stated.
By their numbers in this assay, from the lowest: compound 1; then compound 2; then compounds 3 and 4 (each within the scatter of the next).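

In this assay chloro in place of fluoro on this aromatic carbon gives no change at the digits printed from compound 3 to compound 4 (within the scatter) while chloro in place of hydrogen gives a number 25 percentage points higher from compound 2 to compound 4 (beyond the scatter) at the same carbon. The higher number seen earlier with fluoro is therefore not particular to fluoro, since chloro at this position reads the same. Among these compounds, both halogens stand apart from hydrogen here. Going by these compounds, whether a methoxy group or an amine on this carbon would also keep the number this high stays open. Nothing at hand explains the higher number with either halogen.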